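Halogen removal on the fused ring of the thiosemicarbazone series

The compounds below may be only part of what the source reports. "The series", "measured", "known", "first", "only" and "open" are said of these compounds alone.

Measured compounds:
Compound 1 `NC(=S)N/N=C1/C(=O)N(CN2CCN(c3ccnc4cc(C(F)(F)F)ccc34)CC2)c2cccc(Cl)c21`: 87800 nM
Compound 2 `NC(=S)N/N=C1/C(=O)N(CN2CCN(c3ccnc4cc(C(F)(F)F)ccc34)CC2)c2cccc(Br)c21`: 26400 nM
Compound 3 `NC(=S)N/N=C1/C(=O)N(CN2CCN(c3ccnc4cc(C(F)(F)F)ccc34)CC2)c2cc(Cl)ccc21`: 20100 nM

In an ADME assay on 184B5 cells (Homo sapiens) for cytotoxicity, read by sulforhodamine B assay, with a stated time of 48 h (on this read-out higher numbers stand for weaker inhibition of growth and lower numbers for stronger inhibition of growth), compound 3 gives the lowest of the three numbers, with compound 2 close to it and within the scatter, and compound 1 well apart, beyond the scatter. Within the data shown here, the only measured step that varies a single place, bromo in place of chloro on an aromatic carbon, is a 3.3-fold lower number from compound 1 to compound 2 (0.52 log units; beyond the scatter). Compound 1 and compound 3 share a chloro substituent but not its place on the fused ring, and their two values sit apart beyond the scatter.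

Compound 4 `NC(=S)N/N=C1/C(=O)N(CN2CCN(c3ccnc4cc(C(F)(F)F)ccc34)CC2)c2ccccc21` differs from compound 3 by hydrogen in place of chloro on an aromatic carbon. Among the measured compounds shown here, no measured step removes a halogen outright, so the closest guide is the halogen swap in the step from compound 1 to compound 2, which was modest. A step of similar size, toward a higher number in this assay, is expected for the removal of the chloro group, though its direction is uncertain. The estimate for compound 4 is 35000 nM, in the range 14000 nM to 90000 nM, a step of a 1.7-fold higher number from compound 3 to compound 4 (0.24 log units; within the scatter) from compound 3.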

Compound 4, concentration for 50% growth inhibition: 20200 nM
Estimate against measurement, compound 4: 1.7-fold (0.24 log units) above; the measured number falls inside the stated range.
By their numbers in this assay, from the lowest: compounds 3, 4 and 2 (each within the scatter of the next); then compound 1.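

In this assay, hydrogen in place of the chloro group of compound 3 gives a value that cannot be told apart from that of the chlorinated parent (a 1.0-fold higher number from compound 3 to compound 4 (0.00 log units; within the scatter)), so a halogen is not needed at this place, meta to one fused ring and para to another, for this level of growth inhibition. The same holds for the bromo group of compound 2 (a 1.3-fold lower number from compound 2 to compound 4 (0.12 log units; within the scatter)), while the chloro group of compound 1, at its other place on the fused ring, is the only one whose replacement by hydrogen gives a difference beyond the scatter (a 4.3-fold lower number from compound 1 to compound 4 (0.64 log units; beyond the scatter)). Nothing available accounts for this difference between the two chloro places.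

Still open, going by these compounds, is whether a methoxy group, an amine or a carboxylic acid at the place of the chloro group of compound 3 would separate from compound 4. Also open, on these data alone, is whether a bromo group at that place would match the chloro group.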